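The compounds below may be only part of what the source reports. "The series", "measured", "known", "first", "only" and "open" are said of these compounds alone.

Values in an ADME assay on RAW264.7 cells (Mus musculus) for cytotoxicity, read by MTT assay, with a stated time of 24 h (on this read-out higher numbers stand for lower toxicity in this test and lower numbers for higher toxicity in this test), so far:
- compound 1 `CC/C=C\C[C@H]1C(=O)C=C[C@H]1CC(=O)Oc1ccccc1` (158 uM)
- compound 2 `CC/C=C\C[C@H]1C(=O)C=C[C@H]1CC(=O)Oc1ccc(O)cc1` (49 uM)
- compound 3 `CC/C=C\C[C@H]1C(=O)C=C[C@H]1CC(=O)Oc1ccccc1OC` (not yet measured)

Compound 1 stands highest of the two measured numbers. Going to compound 3 places methoxy in place of hydrogen on an aromatic carbon, ortho to a large group: methoxy in place of hydrogen on an aromatic carbon. For the measured compounds named here, only one measured step bears on this, a 3.2-fold lower number from compound 1 to compound 2 (0.51 log units; beyond the scatter), a modest step with hydroxy as the entering group, so it is a loose guide. In this assay a smaller move toward a lower number is expected, possibly none beyond the scatter. The expected step is a 1.6-fold lower number from compound 1 to compound 3 (0.20 log units; within the scatter). For compound 3 the estimated value is 100 uM, with an expected range from 40 uM to 220 uM.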

Compound 3, half-maximal toxic concentration: 161 uM
For compound 3 the middle estimate is 1.6-fold (0.21 log units) below the measured one; measured number inside the range.
By their numbers in this assay, from the lowest: compound 2; then compounds 1 and 3 (each within the scatter of the next).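

In this assay, methoxy in place of hydrogen on an aromatic carbon, ortho to a large group, gives a 1.0-fold higher number from compound 1 to compound 3 (0.01 log units; within the scatter) and so leaves the number unmoved at this position. A new group on this aromatic ring therefore need not lower the number, unlike hydroxy in a 3.2-fold lower number from compound 1 to compound 2 (0.51 log units; beyond the scatter). No measurement at hand accounts for this result.

Open, going by these compounds, is whether hydroxy ortho to a large group would behave like methoxy or lower the number. Also open, on these data alone, is whether an amine, a carboxylic acid or a longer alkoxy chain would leave the number unmoved here.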